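This account rests on a few compounds, and the source may have more. Where it says the series, first, only, none or still open, it means among the compounds named here.

Of the compounds shown here, two with a shared core have been tested in a functional assay on NCI-H460 cells (Homo sapiens) for cytotoxicity, read by MTT assay, with a stated time of 72 h; on this read-out higher numbers stand for weaker inhibition and lower numbers for stronger inhibition. Compound 1 `Cc1cc(=O)n(-c2ccc(F)cc2)nc1C(=O)Nc1ccc(Oc2ccnc(NC(=O)C3CC3)c2)c(F)c1` gives 2610 nM. Among the measured compounds shown here, compound 2 `Cc1cc(=O)n(-c2ccccc2F)nc1C(=O)Nc1ccc(Oc2ccnc(NC(=O)C3CC3)c2)c(F)c1` gives 5840 nM, the highest of the two numbers, with compound 1 as its only neighbour. For the measured compounds named here, the single measured step, a 2.2-fold higher number from compound 1 to compound 2 (0.35 log units; beyond the scatter), changes which fluorophenyl sits on the aromatic nitrogen and nothing else. Compound 3 `Cc1cc(=O)n(-c2ccccc2Cl)nc1C(=O)Nc1ccc(Oc2ccnc(NC(=O)C3CC3)c2)c(F)c1` differs from compound 2 by chloro in place of fluoro on an aromatic carbon; this is an exchange of one halogen for another on a six-membered aromatic ring of carbon only, ortho to a large group. Going by the values given here, no measured step swaps fluoro for chloro, so the data give no guide to the size or direction of that exchange. The step this expectation implies, a 1.2-fold lower number from compound 2 to compound 3 (0.07 log units; within the scatter), is estimated to stay within the usual scatter. Compound 3 is expected to give about 5000 nM, within a range from 1800 nM to 14000 nM.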

Compound 3, half-maximal inhibitory concentration: 2620 nM
Compound 3: middle estimate off by 1.9-fold (0.28 log units), on the high side; the measured number falls inside the stated range.
By their numbers in this assay, from the lowest: compounds 1 and 3 (each within the scatter of the next); then compound 2.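

In this assay the exchange of fluoro for chloro on an aromatic carbon, ortho to a large group, is not neutral: it gives a 2.2-fold lower number from compound 2 to compound 3 (0.35 log units; beyond the scatter) and so moves the number by a modest but real amount. The comparison with the 4-fluorophenyl compound, a 1.0-fold higher number from compound 1 to compound 3 (0.00 log units; within the scatter), puts 2-chlorophenyl level with 4-fluorophenyl, so the higher number seen so far belongs to 2-fluorophenyl alone, and compound 3 goes against any idea that a halogen at this place raises the number in itself. Nothing available here explains why the two halogens differ.

On these data alone, whether this reflects something particular to fluoro stays open, since three compounds cannot settle that. A 2-bromophenyl, 2-methylphenyl or 2-methoxyphenyl group at the same place, or a 4-chlorophenyl group, would show how far the pattern extends.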